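This account rests on a few compounds, and the source may have more. Where it says the series, first, only, none or still open, it means among the compounds named here.

In a functional assay on LNCaP cells (Homo sapiens) for antiproliferative activity, read by propidium iodide staining, with a stated time of 96 h (on this read-out lower numbers stand for stronger inhibition and higher numbers for weaker inhibition), compound 1 `CC(O)(CSc1ccccc1C(F)(F)F)C(=O)Nc1ccc(S(F)(F)(F)(F)F)cc1` gives 12300 nM, and compound 2 `CC(O)(COc1cccc(OC(F)(F)F)c1)C(=O)Nc1ccc(S(F)(F)(F)(F)F)cc1` gives 11000 nM. Compound 3 `CC(O)(CS(=O)(=O)c1cccc(S(F)(F)(F)(F)F)c1)C(=O)Nc1ccc(C#N)cc1C(F)(F)F` gives 12900 nM. That number stands within the usual scatter of the other two, so these measurements do not separate the compounds. Compound 4 `CC(O)(CS(=O)(=O)c1cccc(S(F)(F)(F)(F)F)c1)C(=O)Nc1ccc([N+](=O)[O-])cc1C(F)(F)F` has not yet been measured. It has nitro in place of cyano on an aromatic carbon of compound 3, a position meta to a trifluoromethyl group and para to a large group: nitro in place of cyano on an aromatic carbon. Within the data shown here, no two tested compounds differ in just one place, so the data offer no direct precedent for this swap. With no such guide, the expectation in this assay is no change beyond the scatter and no firm direction, leaving compound 4 close to compound 3 at 12900 nM. The estimated step is a 1.3-fold lower number from compound 3 to compound 4 (0.11 log units; within the scatter). For compound 4, the expected value is 10000 nM, with an estimated range from 4500 nM to 22000 nM.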

Compound 4, half-maximal inhibitory concentration: 6500 nM
Beside the measured number, compound 4's estimate is 1.5-fold (0.19 log units) above it; the range from low to high includes it.
By their numbers in this assay, from the lowest: compounds 4, 2, 1 and 3 (each within the scatter of the next).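

Among these compounds, the swap of cyano for nitro, on an aromatic carbon meta to a trifluoromethyl group and para to a large group, gives the first direct one-place comparison in this assay, with a 2.0-fold lower number from compound 3 to compound 4 (0.30 log units; within the scatter). Nitro can therefore stand in place of cyano at this position without a step beyond the scatter, so this pair does not show that the choice between these two groups matters here. No supporting measurement is available to explain this result.

The pair says nothing about how an amine or a carboxylic acid would behave on this aromatic carbon. It also leaves open whether the same swap would give a similar step with a different group elsewhere on the molecule.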